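Notes on compound 3: a change of ring substituent

This account rests on a few compounds, and the source may have more. Where it says the series, first, only, none or still open, it means among the compounds named here.

Measured in a functional assay on HCT-116 cells (Homo sapiens) for antiproliferative activity, read by MTT assay, with a stated time of 72 h; a lower number here means a stronger inhibitor, a higher number a weaker inhibitor:
- compound 1 `Cc1ccc(N2CCN(C(=S)SCc3ccc4nc(N)nc(N)c4c3)CC2)c(C)c1`: 4070 nM
- compound 2 `Nc1nc(N)c2cc(CSC(=S)N3CCN(c4ccccc4Cl)CC3)ccc2n1`: 5490 nM

At 5490 nM, compound 2 lies within the scatter of compound 1, so the two values show no order. Compound 3 `Nc1nc(N)c2cc(CSC(=S)N3CCN(c4ccc(F)cc4)CC3)ccc2n1` follows from compound 2 by one change: 4-fluorophenyl in place of 2-chlorophenyl on an amine nitrogen in a ring. In words, 4-fluorophenyl replaces 2-chlorophenyl on an amine nitrogen in a ring. Among the compounds with values here, the only measured step, a 1.3-fold higher number from compound 1 to compound 2 (0.13 log units; within the scatter), changes the group at that same place. No step beyond the scatter is therefore expected in this assay. The estimated change is a 1.2-fold lower number from compound 2 to compound 3 (0.07 log units; within the scatter). For compound 3 the expected value is 4700 nM, with an estimated range of 2000 nM to 10000 nM.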

Compound 3, half-maximal inhibitory concentration: 3270 nM
Compound 3: the middle estimate sits 1.4-fold (0.16 log units) above what was measured; low and high end bracket the measured number.
By their numbers in this assay, from the lowest: compounds 3, 1 and 2 (each within the scatter of the next).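

In this assay 4-fluorophenyl gives a 1.7-fold lower number from compound 2 to compound 3 (0.23 log units; within the scatter) and a 1.2-fold lower number from compound 1 to compound 3 (0.10 log units; within the scatter) on the same amine nitrogen. A third substituted phenyl at this place therefore stands level with 2-chlorophenyl and 2,4-dimethylphenyl, and these three groups show no order. No evidence beyond these values bears on this result.

As far as these compounds go, whether a group without a phenyl ring, such as cyclohexyl or a short alkyl chain, would give a step beyond the scatter remains open. The same holds for a phenyl ring carrying an amine or a carboxylic acid.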